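A few compounds are considered here, and "the series" means these few. Any claim that something is new, unique, unknown or untested is made for them only; others in the source may bear on it.

Measured compounds in an ADME assay on SW480 cells (Homo sapiens) for cytotoxicity, read by MTT assay, with a stated time of 72 h; a lower number here means a stronger inhibitor, a higher number a weaker inhibitor:

Compound 1 `Cc1ccc(N2C(=O)C/C(=C\c3cccc(C(=O)Nc4cccc(F)c4)c3)C2=O)cc1` gives 96900 nM.
Compound 2 `CCCCCN1C(=O)C/C(=C\c2cccc(C(=O)NCCCC)c2)C1=O` gives > 100000 nM, which is a limit of the assay and not a number.
Compound 3 `CCCCCN1C(=O)C/C(=C\c2cccc(C(=O)Nc3ccc(OC)cc3)c2)C1=O` gives > 100000 nM, again a limit of the assay and not a number.

Compound 3 thus sits at the limit of > 100000 nM in this assay, at which 2 of the 3 values shown sit, so its true value cannot be placed. The change to compound 4 `CCCCCN1C(=O)C/C(=C\c2cccc(C(=O)Nc3cccc(F)c3)c2)C1=O` is 3-fluorophenyl in place of 4-methoxyphenyl on an amide-type nitrogen. Among the measured compounds shown here, the only measured step at this amide-type nitrogen, a step that the two limits leave unreadable from compound 2 to compound 3, has a size that cannot be read, so no direction follows from it. Compound 1 carries the same 3-fluorophenyl amide and gives a number close to that limit. Compound 4 is therefore expected to lie near the limit too, at 120000 nM, within 50000 nM to 300000 nM. The expected step that the limit leaves unreadable from compound 3 to compound 4 is estimated to stay within the scatter.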

Compound 4, half-maximal inhibitory concentration: > 100000 nM
Compound 4: only a limit was reported; the forecaster's own chance of this, stated with the estimate: 60%; the middle value lies beyond the limit too.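

In this assay compound 4 gives > 100000 nM, which is a limit and not a number. Its steps to compound 2 and compound 3 cannot be read, so changing the group on the amide-type nitrogen has still produced no measurable difference. From the compounds shown here alone, replacing 4-methylphenyl with pentyl on the ring nitrogen gives an at least 1.0-fold higher number from compound 1 to compound 4 (0.01 log units; that floor lies within the scatter), so the true size of this step stays unknown. Whether a chain ending in an amine or a carboxylic acid on the amide-type nitrogen would give a clear number stays open, since nearly all values shown stop at one limit: the limit of > 100000 nM in this assay, at which 3 of the 4 values shown sit.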